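The compounds below may be only part of what the source reports. "The series", "measured", "known", "first", "only" and "open" are said of these compounds alone.

Compound 1 `Cc1nc(N2CCN(C)CC2)c2nc(-c3ccccc3C(F)(F)F)n(C3CCOCC3)c2n1`: 38%
Compound 2 `Cc1nc(N2CCN(C)CC2)c2nc(-c3cccc(C(F)(F)F)c3)n(C3CCOCC3)c2n1`: 28%
Compound 3 `COc1cccc(-c2nc3c(N4CCN(C)CC4)nc(C)nc3n2C2CCOCC2)c1`: 30%

These numbers come from an ADME assay (liver) for metabolic stability, with Liver microsome (Rattus norvegicus) as the target, read by LC-MS, using microsomes, with a stated time of 30 min, tested at 4 uM; on this read-out lower numbers stand for a less stable compound and higher numbers for a more stable compound. There, compound 3 gives 30%, which lies within the usual scatter of both other compounds, so the three cannot be ranked with confidence.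

The next compound is compound 4 `Cc1nc(N2CCN(C)CC2)c2nc(-c3ccccc3C#N)n(C3CCOCC3)c2n1`, in which 2-cyanophenyl takes the place of 3-methoxyphenyl on an aromatic carbon of the shared core: 2-cyanophenyl in place of 3-methoxyphenyl on an aromatic carbon. Among the measured compounds shown here, no measured compound carries 2-cyanophenyl, so the evidence is indirect. It comes from three measured swaps of the aromatic group at this same place: a number 10 percentage points lower from compound 1 to compound 2 (within the scatter), a number 8 percentage points lower from compound 1 to compound 3 (within the scatter) and a number 2 percentage points higher from compound 2 to compound 3 (within the scatter). Even a number 10 percentage points lower from compound 1 to compound 2 (within the scatter), the largest of the three, stays within the scatter, so no step beyond the scatter is expected for this swap. The expected step is a number 4 percentage points higher from compound 3 to compound 4 (within the scatter), a small one that could easily go either way. The estimated value for compound 4 is 34%, with an expected range of 19% to 50%.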

Compound 4, percent of the compound remaining: 21%
Beside the measured number, compound 4's estimate is 13 percentage points above it; measured number inside the range.
By their numbers in this assay, from the lowest: compounds 4, 2, 3 and 1 (each within the scatter of the next, the first and the last beyond it).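

In this assay, this aromatic carbon now gives its first step beyond the scatter, a modest one, where cyano takes the place of trifluoromethyl on the phenyl ring (a number 17 percentage points lower from compound 1 to compound 4 (beyond the scatter)). The other two steps stay within the scatter (a number 9 percentage points lower from compound 3 to compound 4 (within the scatter); a number 7 percentage points lower from compound 2 to compound 4 (within the scatter)), so the change of group at this place separates compound 4 from compound 1 only. Nothing available explains that step.

Still open, from the compounds shown here alone, is whether the group itself or its place on the phenyl ring matters more, a question that 3-cyanophenyl and 2-methoxyphenyl could help to settle. Also open, going by these compounds, is how this read-out responds to an amine or a carboxylic acid on the phenyl ring.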